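The source may report more compounds than this note shows. Statements on the series, on what has been measured and on what is new or still open speak of the compounds shown alone.

In an ADME assay on PC-3 cells (Homo sapiens) for cytotoxicity, read by WST assay, tested at 100 uM (a higher number here means more inhibition at the concentration tested (going by the name of the read-out), a lower number less inhibition), three amides built on one shared core have been measured so far. Compound 1 `O=C(Nc1cccc(-c2ccco2)c1)C1CCCN(C(=O)c2cc(C(F)(F)F)cc(C(F)(F)F)c2)C1` gives 0%, and compound 2 `COC(=O)c1cccc(NC(=O)C2CCCN(C(=O)c3cc(C(F)(F)F)cc(C(F)(F)F)c3)C2)c1` gives 0%; the step of no change at the digits printed from compound 1 to compound 2 (within the scatter) shows that methoxycarbonyl in place of furan-2-yl on an aromatic carbon leaves the number where it was. Compound 3 `O=C(Nc1ccc(Cl)cc1)C1CCCN(C(=O)c2cc(C(F)(F)F)cc(C(F)(F)F)c2)C1` gives 14%, the highest of the three numbers, with the steps of a number 14 percentage points higher from compound 1 to compound 3 (beyond the scatter) and a number 14 percentage points higher from compound 2 to compound 3 (beyond the scatter) both beyond the scatter but modest in size.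

Compound 4 `O=C(Nc1ccc(Cl)cn1)C1CCCN(C(=O)c2cc(C(F)(F)F)cc(C(F)(F)F)c2)C1` has not yet been measured. It differs from compound 3 by 5-chloropyridin-2-yl in place of 4-chlorophenyl on an amide-type nitrogen. Among the measured compounds shown here, no measured step swaps one six-membered aromatic ring of carbon only on the amide-type nitrogen for one with a hetero atom. The two steps that did change the ring on that nitrogen, a number 14 percentage points higher from compound 1 to compound 3 (beyond the scatter) and a number 14 percentage points higher from compound 2 to compound 3 (beyond the scatter), moved the number only modestly, and no change at the digits printed from compound 1 to compound 2 (within the scatter) did not move it at all. The expected step is therefore small, a number 4 percentage points lower from compound 3 to compound 4 (within the scatter), with the number likely to stay near that of compound 3. Compound 4 is accordingly estimated at 10%, within a range from 0% to 30%.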

Compound 4, a percentage reported as inhibition, at one concentration (the size of the read-out at that concentration, not a potency): 0%
For compound 4 the middle estimate is 10 percentage points above the measured one, within the range that was stated.
By their numbers in this assay, from the lowest: compounds 1, 2 and 4 (each within the scatter of the next); then compound 3.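

In this assay, among the compounds shown here, the step of a number 14 percentage points lower from compound 3 to compound 4 (beyond the scatter) is the first measured exchange on the amide-type nitrogen of a six-membered aromatic ring of carbon only for one with a hetero atom, and it shows that this single change is enough to take away the modest reading of compound 3. Compound 4 keeps a chlorine on its ring, yet its reading shows no change at the digits printed from compound 2 to compound 4 (within the scatter) and no change at the digits printed from compound 1 to compound 4 (within the scatter) in this same comparison, so a chlorine-bearing ring on this nitrogen does not by itself give a reading above those of the compounds without chlorine, and compound 3 is now the only one of the four that stands apart. No measurement on hand explains why this exchange has this effect.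

The compounds shown leave open whether the ring nitrogen itself matters or only its place in the ring, since 5-chloropyridin-2-yl is the only ring with a hetero atom here. They also leave open whether a pyridine ring carrying an amine or a carboxylic acid in place of the chlorine would read any differently on this amide-type nitrogen.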